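The source may hold more compounds than are shown below. What is called first, only, known or untested is meant among the compounds shown, and "the series" means these compounds.

Values in (a functional assay on RS4-11 cells (Homo sapiens) for inhibition, read by CCK-8 assay, with a stated time of 48 h; on this read-out lower numbers stand for stronger inhibition and higher numbers for weaker inhibition):
compound 1 (`O=C(NCCNS(=O)(=O)c1ccc(-c2ccccc2O[C@H]2CC[C@H](O)CC2)s1)Nc1cc(C(F)(F)F)cc(C(F)(F)F)c1`) gives (10100 nM)
compound 2 (`O=C(NCCNS(=O)(=O)c1ccc(-c2ccccc2O[C@H]2CC[C@@H](O)CC2)s1)Nc1ccc([N+](=O)[O-])cc1`) gives (12400 nM)
compound 3 (`O=C(NCCNS(=O)(=O)c1ccc(-c2ccccc2O[C@H]2CC[C@H](O)CC2)s1)Nc1ccc([N+](=O)[O-])cc1`) gives (4100 nM)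

Compound 2 lies within the scatter of compound 1. For the measured compounds named here, the only measured step that starts from it is modest but beyond the scatter (a 3.0-fold lower number from compound 2 to compound 3 (0.48 log units; beyond the scatter)) and involves configuration alone (the fact that compounds 2 and 3 differ only in the configuration as drawn).

Compound 4 (`O=[N+]([O-])c1ccc(NC(=S)NCCNS(=O)(=O)c2ccc(-c3ccccc3O[C@H]3CC[C@@H](O)CC3)s2)cc1`) keeps the rest of compound 2 and differs as follows: (a group of 12 heavy atoms (7 carbon, 2 nitrogen, 2 oxygen, 1 sulfur; one six-membered aromatic ring of carbon only) in place of a group of 12 heavy atoms (7 carbon, 2 nitrogen, 3 oxygen; one six-membered aromatic ring of carbon only), on an amine nitrogen). The (4-nitrophenyl)carbamoyl group leaves its place on an amine nitrogen. Going by the values given here, no measured step covers this exchange, and the configuration step does not carry over to it. The expectation therefore rests on compound 2 at (12400 nM), and no step beyond the scatter is expected in either direction in this assay on this basis. The expected change is small (a 1.4-fold lower number from compound 2 to compound 4 (0.14 log units; within the scatter)). Compound 4 is estimated at 9000 nM with an expected range from 3500 nM to 22000 nM here.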

Compound 4, half-maximal inhibitory concentration: 9400 nM
The estimate for compound 4 lay 1.0-fold (0.02 log units) below the measured number; measured number inside the range.
By their numbers in this assay, from the lowest: compound 3; then compounds 4, 1 and 2 (each within the scatter of the next).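

In this assay, putting sulfur in place of one oxygen in the (4-nitrophenyl)carbamoyl group on the amine nitrogen gives a 1.3-fold lower number from compound 2 to compound 4 (0.12 log units; within the scatter). At this position, with the configuration of compound 2 held fixed, the exchange therefore does not separate the two compounds. Nothing available bears on the reason for this outcome.

From the compounds shown here alone, whether the same exchange holds in the configuration of compound 3 or with the bis(trifluoromethyl)phenyl group of compound 1 remains open. So does the effect of a guanidine or a simple amide at this place.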